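This account rests on a few compounds, and the source may have more. Where it says the series, first, only, none or still open, it means among the compounds named here.

Compound 1 `CC1=C(/C=N/NC(N)=O)C(C)(C)CC=C1` and compound 2 `CC1=C(/C=N/NC(N)=S)C(C)(C)CC=C1` share one core and differ only in the terminal group on the amine nitrogen. In an assay on cells for inhibition of Amine oxidase [flavin-containing] A (Homo sapiens), read by fluorescence and spectrophotometry, with a stated time of 20 min (a higher number here means a weaker inhibitor, a lower number a stronger inhibitor), compound 1 gives 164000 nM, while compound 2 gives 56800 nM; the step of a 2.9-fold lower number from compound 1 to compound 2 (0.46 log units; beyond the scatter) is the only measured one, and compound 2 stands lowest of the two numbers. Compound 3 `CC1=C(/C=N/NC(=S)Nc2ccccc2)C(C)(C)CC=C1` carries phenyl in place of hydrogen on an amide-type nitrogen. For the measured compounds named here, no measured step covers a change of this kind, so the expectation rests on little. Compound 3 is expected to give 20000 nM in this assay, within 4000 nM to 100000 nM. That estimate means an expected step of a 2.8-fold lower number from compound 2 to compound 3 (0.45 log units; beyond the scatter), modest and toward a lower number.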

Compound 3, half-maximal inhibitory concentration: 19500 nM
Beside the measured number, compound 3's estimate is 1.0-fold (0.01 log units) above it; measured number inside the range.
By their numbers in this assay, from the lowest: compound 3; then compound 2; then compound 1.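

On the amide-type nitrogen whose other neighbour is the thiocarbonyl carbon, the change from amino to anilino in this assay gives a 2.9-fold lower number from compound 2 to compound 3 (0.46 log units; beyond the scatter), so a phenyl at this place lowers the number rather than raising it. For the compounds shown here, this is the first measured change at this place, and it extends the series beyond the swap of the terminal group that separates compound 1 from compound 2. Nothing given here explains the step. The compounds shown leave open whether a methyl, a longer alkyl chain or a benzyl group would act as phenyl does. They also leave open whether phenyl would lower the number on the carbonyl counterpart, compound 1.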